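This account rests on a few compounds, and the source may have more. Where it says the series, first, only, none or still open, it means among the compounds named here.

Measured so far:
compound 1 `C[C@H](NC(=O)CN(c1nc(Cl)nc2[nH]cnc12)C1CC1)C(=O)OCc1ccccc1` — 36.1%
compound 2 `C[C@H](NC(=O)CN(c1nc(Cl)nc2[nH]cnc12)C1CC1)C(=O)O` — 28.4%

For the measured compounds named here, in a functional assay on the whole organism (Tail, strain ICR) with Mus musculus as the target, in the tail flick test, with a stated time of 120 min, at a dose of 25 umol/kg by the oral route (a higher number here means a stronger effect of the compound at the dose given, a lower number a weaker effect), compound 1 gives 36.1%, the higher of the two numbers known, though the gap to compound 2, a number 7.7 percentage points lower from compound 1 to compound 2 (within the scatter), lies within the scatter. That only known step swaps a benzyl for a hydrogen on the oxygen of the ester; it says nothing about the saturated chain carbon where compound 3 `NC(=O)C[C@H](NC(=O)CN(c1nc(Cl)nc2[nH]cnc12)C1CC1)C(=O)OCc1ccccc1` differs from compound 1. The difference there is carbamoyl in place of hydrogen on a saturated chain carbon, two bonds along the chain from an amide-type nitrogen and a carbonyl carbon. Going by the values given here, no measured pair bears on this change, so the expectation for compound 3 rests on compound 1 alone, with a wide range to cover an unknown direction. The estimate for compound 3 in this assay is therefore a step of a number 3.1 percentage points lower from compound 1 to compound 3 (within the scatter), with an expected value of 33% and a range from 12% to 55%.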

Compound 3, a percentage reported as activity, at one dose (the size of the read-out at that dose, not a potency): 15.1%
Compound 3: middle estimate off by 17.9 percentage points, on the high side; the measured number falls inside the stated range.
By their numbers in this assay, from the lowest: compound 3; then compounds 2 and 1 (each within the scatter of the next).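

In this assay the change gives a number 21 percentage points lower from compound 1 to compound 3 (beyond the scatter) and so, unlike the ester step, it clears the usual scatter. For the compounds shown here, this is the first sign that the saturated chain carbon responds to what it carries: read one bond further out, replacing methyl with carbamoylmethyl lowers the effect at the dose given. Nothing available explains this drop. 

Carbamoyl is the only added group seen at this carbon, so it remains open whether a carboxylic acid, an amine or a longer chain of carbons there would lower the number as much, less or not at all. Going by these compounds alone, it is also open whether carbamoyl would have the same effect with the free acid of compound 2, since here it is seen only with the benzyl ester.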